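The source may hold more compounds than are shown below. What is called first, only, known or untested is meant among the compounds shown, and "the series" means these compounds.

Working notes on the series, read in a functional assay (trachea) with Cavia porcellus as the target; on this read-out higher numbers stand for weaker inhibition and lower numbers for stronger inhibition. Compound 1 `CCCCn1nc(-c2cccnc2)c2ccccc2c1=O` gives 2290 nM. Going by the values given here, compound 2 `O=c1c2ccccc2c(-c2cccnc2)nn1CCSc1ccccc1` gives 9120 nM, the highest of the two numbers so far, which makes it the weaker inhibitor of the pair. Compound 3 `O=c1c2ccccc2c(-c2cccnc2)nn1CCSc1ncccn1` has pyrimidin-2-yl in place of phenyl on a sulfur, and the rest of compound 2 stays unchanged. Among the compounds with values here, no measured step touches this ring. Within the data shown here, the only guide is the modest step of a 4.0-fold higher number from compound 1 to compound 2 (0.60 log units; beyond the scatter), beyond the scatter, with phenylsulfanyl in place of ethyl on a saturated chain carbon. On that basis a change of similar or smaller size is expected in this assay, and the data do not settle its direction. The expected step, leaning slightly lower, is a 1.7-fold lower number from compound 2 to compound 3 (0.22 log units; within the scatter). For compound 3 the estimated value is 5500 nM, with an expected range of 1700 nM to 17000 nM.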

Compound 3, half-maximal inhibitory concentration: 11000 nM
The estimate for compound 3 lay 2.0-fold (0.30 log units) below the measured number; the measured number falls inside the stated range.
By their numbers in this assay, from the lowest: compound 1; then compounds 2 and 3 (each within the scatter of the next).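

In this assay, pyrimidin-2-yl in place of phenyl on a sulfur gives a 1.2-fold higher number from compound 2 to compound 3 (0.08 log units; within the scatter), so the entry of a ring with 2 hydrogen-bond acceptors, where phenyl has 0, does not separate compound 3 from compound 2. With (pyrimidin-2-yl)sulfanyl in place of ethyl on a saturated chain carbon, the series shows a 4.8-fold higher number from compound 1 to compound 3 (0.68 log units; beyond the scatter), so this sulfur-linked ring, like the phenylsulfanyl group, leaves the number beyond the scatter on the weaker side of compound 1. At this position, then, the two aromatic rings on sulfur cannot be told apart, and the gap to compound 1 remains. No supporting evidence is at hand to explain either step.

Open, on these data alone, is whether the sulfur itself matters, as an oxygen in its place would test. Also open, as far as these compounds go, is how an amine or a carboxylic acid at the end of the chain would read compared with these aromatic rings.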